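Cytotoxicity of a Cyclopropylidene Nucleoside Series on Lymphoblasts

The compounds below may be only part of what the source reports. "The series", "measured", "known", "first", "only" and "open" are said of these compounds alone.

Compound 1 `CNc1nc(N)nc2c1ncn2/C=C1/CC1(CO)CO`: > 20000 nM in an ADME assay on CCRF-HSB-2 cells (Homo sapiens) for cytotoxicity, with a stated time of 7 days (on this read-out higher numbers stand for lower toxicity in this test and lower numbers for higher toxicity in this test), a limit of the assay.
Compound 2 `C=CCOc1nc(N)nc2c1ncn2/C=C1/CC1(CO)CO`: > 20000 nM, a limit of the assay.
Compound 3 `CCCSc1nc(N)nc2c1ncn2/C=C1/CC1(CO)CO`: 98000 nM.

Compound 1 stands at the assay limit, (the limit of > 20000 nM in this assay, at which 2 of the 3 values shown sit), so its position among the three is not readable. The steps a step that the two limits leave unreadable from compound 1 to compound 2 and a step that the limit leaves unreadable from compound 1 to compound 3 also stay unreadable. Compound 4 `CC(C)CNc1nc(N)nc2c1ncn2/C=C1/CC1(CO)CO` carries isopropyl in place of hydrogen on a saturated chain carbon bound to a nitrogen on an aromatic ring. For the measured compounds named here, no measured step changes the methylamino in this way, so the three values give only a rough guide. Compound 4 is therefore expected to stay near the limit, with the step that the limit leaves unreadable from compound 1 to compound 4 estimated as small. The estimate for compound 4 is 30000 nM, ranging from 10000 nM to 100000 nM.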

Compound 4, half-maximal cytotoxic concentration: > 20000 nM
Compound 4 gave a limit, no number; the forecaster's own chance of this, stated with the estimate: 65%; the middle value lies beyond the limit too.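

For the compounds shown here, compound 4 also sits at a limit of the assay, so no step linking it to compound 1, compound 2 or compound 3 can be read: the limit of > 20000 nM in this assay, at which 3 of the 4 values shown sit. The compounds shown leave open whether isobutylamino in place of methylamino changes cytotoxicity at all in this assay.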